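Tert-butyl for Fluoro on the Outer Ring

The source may report more compounds than this note shows. Statements on the series, on what has been measured and on what is new or still open speak of the compounds shown alone.

Measured compounds:
compound 1 `COc1cccc(CNCCCNc2ccnc3cc(C4CCCCC4)ccc23)c1O` – 9.47
compound 2 `COc1cccc(CNCCCNc2ccnc3cc(-c4ccc(F)cc4)ccc23)c1O` – 9.47

In a physicochemical assay for acid dissociation, compound 1 gives 9.47. Compound 2 gives 9.47 in this assay. Compound 2 therefore stands level with compound 1 at the digits shown; the only measured step, no change at the digits printed from compound 1 to compound 2 (within the scatter), lies within the scatter, although it exchanged cyclohexyl for 4-fluorophenyl on an aromatic carbon.

Compound 3 `COc1cccc(CNCCCNc2ccnc3cc(-c4ccc(C(C)(C)C)cc4)ccc23)c1O` is not yet measured. It differs from compound 2 by tert-butyl in place of fluoro on an aromatic carbon. Within the data shown here, the one step that bears on this, no change at the digits printed from compound 1 to compound 2 (within the scatter), changed a group on an aromatic carbon of the shared core and left the acid dissociation constant unmoved. A smaller exchange on the outer ring is therefore expected to produce no step beyond the scatter, no change at the digits printed from compound 2 to compound 3 (within the scatter). For compound 3 the acid dissociation constant is estimated at 9.47, with a range from 9.15 to 9.8.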

Compound 3, acid dissociation constant: 9.47
For compound 3 middle estimate and measured number coincide at the digits printed; low and high end bracket the measured number.
By their numbers in this assay, from the lowest: compounds 1, 2 and 3 (each within the scatter of the next).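

In this assay, replacing fluoro with tert-butyl on the outer ring, which takes out 1 heavy atom and puts in 4, gives no change at the digits printed from compound 2 to compound 3 (within the scatter), so a change in the size of the group on this ring leaves the read-out unmoved. Exchanging the whole group on the shared core, cyclohexyl for 4-(tert-butyl)phenyl, gives no change at the digits printed from compound 1 to compound 3 (within the scatter), which puts three different groups at this place within the scatter of one another. No supporting measurement is available to explain this flat result.

Fluoro and tert-butyl both count no hydrogen-bond donors, no hydrogen-bond acceptors and no net charge, so the effect of an amine or a carboxylic acid on the outer ring remains open. Also open, on these data alone, is whether a longer chain at this place would leave the number as level.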